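A few compounds are considered here, and "the series" means these few. Any claim that something is new, unique, unknown or untested is made for them only; others in the source may bear on it.

Results in an ADME assay on a cell-free system (serum) for metabolic stability (on this read-out higher numbers stand for a longer-lived compound and lower numbers for a shorter-lived compound), so far are all limits of the assay and not numbers. Compound 1 `CC(C)(C)c1cc(OC(=O)c2ccc(Cl)cc2)ccc1O` gives < 0.25 h as a limit. Compound 2 `CC(C)(C)c1cc(NC(=O)c2ccc(Cl)cc2Cl)cc(C(C)(C)C)c1O` gives > 1 h as a limit. Compound 3 `CC(C)(C)c1cc(NC(=O)c2c(Cl)cc(N)cc2Cl)ccc1O` gives > 1 h as a limit too. That places compound 3 at the limit of > 1 h in this assay, at which 2 of the 3 values shown sit, and so at the longer-lived end of the results. Compound 4 `CC(C)(C)c1cc(NC(=O)c2c(Cl)cc(NCc3cccs3)cc2Cl)ccc1O` differs from compound 3 in one place: (thiophen-2-yl)methyl in place of hydrogen on a nitrogen on an aromatic ring and the rest of the structure is shared. Among the measured compounds shown here, compound 3 at > 1 h is the only close neighbour of compound 4 and no measured pair shows this change, so no step beyond the usual scatter is expected in this assay in either direction. The estimated change is a step that the limit leaves unreadable from compound 3 to compound 4 and is expected to be small. For compound 4 the expected half-life is 1.5 h with an estimated range of 0.7 h to 3 h around it.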

Compound 4, half-life: > 1 h
Compound 4 was reported as a limit; the forecaster's own chance of this, stated with the estimate: 75%; the middle value does not contradict the limit.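

In this assay, among the compounds shown here, compound 3 and compound 4 both give only a limit and not a number, so no step between them can be read. As far as these compounds go, how long either compound really lasts, and whether (thiophen-2-yl)methyl in place of hydrogen changes that, stays open.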